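Swapping the Terminal Amine on the Vasopressin Side Chain

This account rests on a few compounds, and the source may have more. Where it says the series, first, only, none or still open, it means among the compounds named here.

compound 1 `Cc1ccccc1C(=O)Nc1ccc(C(=O)N2CCCC(NCCCN3CCCCC3)c3cc(Cl)ccc32)c(C)c1` — 13 nM
compound 2 `Cc1ccccc1C(=O)Nc1ccc(C(=O)N2CCCC(NCCC(=O)N3CCOCC3)c3cc(Cl)ccc32)c(C)c1` — 3.8 nM
compound 3 `Cc1ccccc1C(=O)Nc1ccc(C(=O)N2CCCC(NCCCN3CCN(C)CC3)c3cc(Cl)ccc32)c(C)c1` — 12 nM

Three compounds share one core and differ only in the tail of the amine-bearing chain. In an assay on HEK293 cells for displacement of a labelled ligand from Vasopressin V2 receptor (Homo sapiens), read by HTRF, with a stated time of 2 h (on this read-out higher numbers stand for weaker inhibition and lower numbers for stronger inhibition), compound 1 gives 13 nM, compound 2 gives 3.8 nM and compound 3 gives 12 nM. Compound 3 stands second highest of the three; the step of a 1.1-fold lower number from compound 1 to compound 3 (0.03 log units; within the scatter) lies within the scatter, whereas a 3.2-fold higher number from compound 2 to compound 3 (0.50 log units; beyond the scatter).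

Compound 4 `CCN(CC)CCCNC1CCCN(C(=O)c2ccc(NC(=O)c3ccccc3C)cc2C)c2ccc(Cl)cc21` carries diethylamino in place of 4-methylpiperazin-1-yl on a saturated chain carbon, three bonds along the chain from an amine nitrogen. Among the compounds with values here, the one measured step that bears on this is a 1.1-fold lower number from compound 1 to compound 3 (0.03 log units; within the scatter), an exchange of one amine for another with no change beyond the scatter; the steps of a 3.4-fold lower number from compound 1 to compound 2 (0.53 log units; beyond the scatter) and a 3.2-fold higher number from compound 2 to compound 3 (0.50 log units; beyond the scatter) involve a carbonyl and are of a different kind. Compound 4 is therefore expected to show no step beyond the scatter in this assay, no change at the digits printed from compound 3 to compound 4 (within the scatter). The estimate for compound 4 is 12 nM, between 5 nM and 30 nM.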

Compound 4, inhibition constant in the Vasopressin V2 receptor assay: 31 nM
Estimate against measurement, compound 4: 2.6-fold (0.41 log units) below, outside the stated range (above it).
By their numbers in the Vasopressin V2 receptor assay, from the lowest: compound 2; then compounds 3 and 1 (each within the scatter of the next); then compound 4.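

In the Vasopressin V2 receptor assay the exchange of one terminal amine for another at this place does not always stay within the scatter: diethylamino, the only one of these amines with no ring, stands in compound 4, which gives 31 nM, with a 2.6-fold higher number from compound 3 to compound 4 (0.41 log units; beyond the scatter) and a 2.4-fold higher number from compound 1 to compound 4 (0.38 log units; beyond the scatter). Against the (morpholin-4-yl)carbonyl of compound 2, the (diethylamino)methyl gives an 8.2-fold higher number from compound 2 to compound 4 (0.91 log units; beyond the scatter). In a physicochemical assay for solubility, measured as thermodynamic solubility, with a stated time of 24 h (a higher number here means a more soluble compound, a lower number a less soluble compound), the same exchange shows no change at the digits printed from compound 3 to compound 4 (within the scatter): compound 3 gives 2.3 ug/mL and compound 4 gives 2.3 ug/mL.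

Nothing given here accounts for these steps. From the compounds shown here alone, whether dimethylamino or pyrrolidin-1-yl at this place would stand with diethylamino or with the six-membered ring amines remains open.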